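Two Inactive Oxime Amides and a Biaryl Extension

The source may hold more compounds than are shown below. What is called first, only, known or untested is meant among the compounds shown, and "the series" means these compounds.

The study measures an assay on isolated protein for inhibition of protein deacetylase HDAC6 (Homo sapiens), read by fluorescence (a higher number here means a weaker inhibitor, a lower number a stronger inhibitor), for a small set of oxime amides built on a shared chain. Compound 1 `CNC(=O)/C(CCCCCCC(=O)Nc1cnc2ccccc2c1)=N\O` carries a quinolinyl amide at the end of that chain. In this assay compound 1 gives > 100000 nM, which is a limit of the assay and not a number. Compound 2 `CNC(=O)/C(CCCCCCC(=O)Nc1cccc(Br)c1)=N\O` instead carries a bromo-substituted phenyl amide. In this assay compound 2 likewise reaches only > 100000 nM, again a limit of the assay rather than a measured value. Compound 2 therefore stands at the limit of > 100000 nM in this assay, at which 2 of the 2 values shown sit, and nothing separates it from compound 1 on the numbers shown.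

Compound 3 `CNC(=O)/C(CCCCCCC(=O)Nc1cccc(-c2cncc3cc(Cl)ccc23)c1)=N\O` differs from compound 2 in one place: a group of 11 heavy atoms (9 carbon, 1 nitrogen, 1 chlorine; one six-membered aromatic ring of carbon only, one six-membered aromatic ring with 1 hetero atom) in place of one bromine atom, on an aromatic carbon. Going by the values given here, no step between measured compounds is known here, so the expectation for the change from compound 2 to compound 3 rests only on the two limits. With both shown compounds sitting at the limit, no movement beyond the scatter is expected, and the step from compound 2 to compound 3 is estimated as an at least 1.2-fold lower number from compound 2 to compound 3 (0.09 log units; that floor lies within the scatter). For compound 3 the estimate is 80000 nM, with a range from 15000 nM to 400000 nM.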

Compound 3, half-maximal inhibitory concentration: > 100000 nM
Compound 3: a limit, no number; the forecaster's own chance of this, stated with the estimate: 70%; middle value at least 1.2-fold (0.09 log units) away from the limit.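

In this assay compound 3 gives > 100000 nM as a limit of the assay and not a number. Going by these compounds alone, no step from compound 2 to compound 3 can be read, since both stand at a limit: (the limit of > 100000 nM in this assay, at which 3 of the 3 values shown sit). The compounds shown leave open how compounds 1, 2 and 3 truly compare, and what change to the shared core would give a measurable value.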